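The compounds below may be only part of what the source reports. "The series", "measured", "known", "first", "only" and "open" are said of these compounds alone.

Measured in an assay on isolated protein for inhibition of Rho-associated protein kinase 2 (Homo sapiens), read by scintillation counting, radiometric assay and 33P incorporation, with a stated time of 40 min, in the presence of a further agent that is not named here; on this read-out higher numbers stand for weaker inhibition and lower numbers for stronger inhibition:
compound 1 `CC(=O)Nc1cccc(NC(=O)COc2ccc3c(=O)ccoc3c2)c1` gives 136 nM
compound 2 `CCc1ccc(C(=O)Nc2cccc(NC(=O)COc3ccc4c(=O)ccoc4c3)c2)cc1` gives 24 nM
compound 3 `CC(C)(C)c1ccc(C(=O)Nc2cccc(NC(=O)COc3ccc4c(=O)ccoc4c3)c2)cc1` gives 34 nM

Compound 3 holds the second highest of the three numbers in this assay; its nearest neighbour is compound 2, within the scatter, and its furthest is compound 1, beyond it. The step to compound 4 `N#Cc1ccc(C(=O)Nc2cccc(NC(=O)COc3ccc4c(=O)ccoc4c3)c2)cc1` is cyano in place of tert-butyl on an aromatic carbon. Among the measured compounds shown here, no measured step exchanges an alkyl for cyano, so only indirect steps bear on it. The move from the simple acetamide to an aryl amide gives a modest gain: a 5.7-fold lower number from compound 1 to compound 2 (0.75 log units; beyond the scatter) and a 4.0-fold lower number from compound 1 to compound 3 (0.60 log units; beyond the scatter). Changing the alkyl on that ring alters little: a 1.4-fold higher number from compound 2 to compound 3 (0.15 log units; within the scatter). The aryl amide itself appears to carry the gain, the group on that aromatic carbon contributing little between the two alkyls shown; how cyano behaves there is untested. The expected step is therefore a 1.3-fold higher number from compound 3 to compound 4 (0.12 log units; within the scatter), within or just beyond the scatter, with wide uncertainty. For compound 4 the estimate is 45 nM, with a range from 15 nM to 140 nM.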

Compound 4, half-maximal inhibitory concentration: 15 nM
Compound 4: middle estimate off by 3.0-fold (0.48 log units), on the high side, within the range that was stated.
By their numbers in this assay, from the lowest: compounds 4, 2 and 3 (each within the scatter of the next, the first and the last beyond it); then compound 1.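

In this assay, the group on this aromatic carbon is not neutral to every exchange: cyano in place of tert-butyl gives a 2.3-fold lower number from compound 3 to compound 4 (0.36 log units; beyond the scatter) and so moves the number beyond the scatter, which the exchange between the two alkyls did not do. Cyano in place of ethyl gives a 1.6-fold lower number from compound 2 to compound 4 (0.20 log units; within the scatter) and stays within the scatter, so the nitrile separates from tert-butyl but not from ethyl, and 4-cyanophenyl in place of methyl gives a 9.1-fold lower number from compound 1 to compound 4 (0.96 log units; beyond the scatter) in the same direction as the two alkyl-substituted aryl amides. Nothing available here explains the effect of the nitrile.

As far as these compounds go, whether an amine or a carboxylic acid on the same aromatic carbon would match the nitrile remains open. So does whether cyano would give a similar number elsewhere on that ring.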